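Exchanging a hydroxycarbamoyl pyrimidinyl group for a long chain

The compounds below may be only part of what the source reports. "The series", "measured", "known", "first", "only" and "open" are said of these compounds alone.

Of the compounds shown here, three sharing one core have been measured in a functional assay on NCI-H1299 cells (Homo sapiens) for antiproliferative activity, read by CCK-8 assay, with a stated time of 72 h (a higher number here means a weaker inhibitor, a lower number a stronger inhibitor), so far. For the measured compounds named here, compound 1 `CCOc1cc(C(C)(C)C)ccc1C1=NC(c2ccc(Cl)cc2)C(c2ccc(Cl)cc2)N1C(=O)N1CCN(CCCCCC(=O)NO)CC1` gives 9390 nM and compound 2 `CCOc1cc(C(C)(C)C)ccc1C1=NC(c2ccc(Cl)cc2)C(c2ccc(Cl)cc2)N1C(=O)N1CCN(Cc2ccc(C(=O)NO)cc2)CC1` gives 3000 nM in this test, and the one step beyond the scatter among them is a 3.1-fold lower number from compound 1 to compound 2 (0.50 log units; beyond the scatter) as a modest change. Compound 3 `CCOc1cc(C(C)(C)C)ccc1C1=NC(c2ccc(Cl)cc2)C(c2ccc(Cl)cc2)N1C(=O)N1CCN(c2ncc(C(=O)NO)cn2)CC1` gives 5450 nM and lies within the scatter of both others, with a 1.8-fold higher number from compound 2 to compound 3 (0.26 log units; within the scatter) on one side.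

Compound 4 `CCOc1cc(C(C)(C)C)ccc1C1=NC(c2ccc(Cl)cc2)C(c2ccc(Cl)cc2)N1C(=O)N1CCN(CCCCCCCC(=O)NO)CC1` has 7-(hydroxycarbamoyl)heptyl in place of 5-(hydroxycarbamoyl)pyrimidin-2-yl on an amine nitrogen in a ring and so returns to an open chain. Going by the values given here, the nearest precedent is compound 1 with its shorter chain, and a 1.7-fold lower number from compound 1 to compound 3 (0.24 log units; within the scatter) stayed within the scatter. Among the compounds with values here, no measured pair isolates chain length. In this assay no change beyond the scatter is therefore expected, and the estimated step is a 1.1-fold higher number from compound 3 to compound 4 (0.04 log units; within the scatter) only. The expected value for compound 4 is 6000 nM with an estimated range from 2500 nM to 14000 nM on repeated measurement.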

Compound 4, half-maximal inhibitory concentration: 7760 nM
For compound 4 the middle estimate is 1.3-fold (0.11 log units) below the measured one; the range from low to high includes it.
By their numbers in this assay, from the lowest: compounds 2, 3, 4 and 1 (each within the scatter of the next, the first and the last beyond it).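

In this assay the open chain and the ring are not told apart at this amine nitrogen, with a 1.4-fold higher number from compound 3 to compound 4 (0.15 log units; within the scatter), and lengthening the chain also leaves the number within the scatter, with a 1.2-fold lower number from compound 1 to compound 4 (0.08 log units; within the scatter). The longer chain nevertheless stays separated from the 4-(hydroxycarbamoyl)benzyl group of compound 2, with a 2.6-fold higher number from compound 2 to compound 4 (0.41 log units; beyond the scatter), as the shorter chain of compound 1 did, although compound 3 goes against any split between rings and chains by lying within the scatter of compound 2. Nothing available accounts for these steps.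

Still open is how a much shorter chain would behave at this position, since only two chain lengths are shown. Also open, as far as these compounds go, is whether a carboxylic acid or a primary amide in place of the hydroxycarbamoyl group would keep these numbers.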